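Two chloro positions on a shared hydrazone core

The source may hold more compounds than are shown below. What is called first, only, known or untested is meant among the compounds shown, and "the series" means these compounds.

Measured compounds:
- compound 1, `CC(=O)/C(=N\c1ccccc1)NNc1ccccc1C`, 526 nM
- compound 2, `CC(=O)/C(=N\c1ccc(Cl)cc1)NNc1ccccc1C`, 1830 nM
- compound 3, `CC(=O)/C(=N\c1ccccc1)NNc1ccccc1C(F)(F)F`, 2260 nM

The three compounds were examined in an assay on isolated protein for binding affinity to corticotropin-releasing factor receptor 1 (Homo sapiens); on this read-out higher numbers stand for weaker inhibition and lower numbers for stronger inhibition. Compound 1 is the parent of the set and in this assay gives 526 nM. Compound 2 carries the change (chloro in place of hydrogen on an aromatic carbon), and the step is a 3.5-fold higher number from compound 1 to compound 2 (0.54 log units; beyond the scatter). Compound 3 differs from compound 1 by trifluoromethyl in place of methyl on an aromatic carbon, with a step of a 4.3-fold higher number from compound 1 to compound 3 (0.63 log units; beyond the scatter). Compound 3 and compound 2 stand within the scatter of each other, so no order between them can be read.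

Compound 4, `CC(=O)/C(=N\c1ccccc1Cl)NNc1ccccc1C(F)(F)F`, is not yet measured. It differs from compound 3 by chloro in place of hydrogen on an aromatic carbon. This is the same kind of change as that from compound 1 to compound 2, but not the same: in compound 2 the chloro sits para to a large group, whereas in compound 4 it sits ortho to a large group. The cores of compound 3 and compound 4 differ from those of compound 1 and compound 2 by the trifluoromethyl in place of methyl already described.

Going by the values given here, since the only measured step of this kind, from compound 1 to compound 2, weakened binding, and the changed surroundings of the chloro give no measured guide, compound 4 is expected to show a step of a 2.2-fold higher number from compound 3 to compound 4 (0.34 log units; beyond the scatter), wider in its uncertainty than that earlier step. The estimate for compound 4 in this assay is 5000 nM, between 1500 nM and 16000 nM.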

Compound 4, inhibition constant: > 10000 nM
Compound 4 was reported as a limit; the forecaster's own chance of this, stated with the estimate: 15%; middle value at least 2.0-fold (0.30 log units) from the limit.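

In this assay, compound 4 is reported only as a limit, > 10000 nM, and not as a number. Even so, chloro in place of hydrogen on an aromatic carbon can be read as an at least 4.4-fold higher number from compound 3 to compound 4 (0.64 log units; beyond the scatter), a step beyond the scatter on the trifluoromethyl core. This shows that the direction of the change carried over between these two cores, with a higher number on each, but it does not show whether the change has a larger effect on one core than on the other, and the two cases also differ in the place of the chloro, which stands ortho to a large group only in compound 4: the same change on two cores in this assay, a 3.5-fold higher number (0.54 log units; beyond the scatter) from compound 1 to compound 2 and an at least 4.4-fold higher number (0.64 log units; beyond the scatter) from compound 3 to compound 4; the limit leaves it open whether they differ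

The compounds shown leave open how much of the step belongs to the core and how much to the place of the chloro, since neither core carries the chloro in both places. They also leave open how a fluoro group, a methoxy group or an amine on that aromatic carbon would read in this assay, and whether any such group would keep the number lower than chloro does.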